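The source may hold more compounds than are shown below. What is called first, only, known or untested is meant among the compounds shown, and "the series" means these compounds.

Measured so far:
- compound 1 `CC1=C(C(=O)Nc2cccc(Cl)c2)C(c2cccs2)NC(=O)N1` — > 100000 nM
- compound 2 `CC1=C(C(=O)Nc2ccc(Cl)cc2)C(c2cccs2)NC(=O)N1` — > 100000 nM
- compound 3 `CC1=C(C(=O)Nc2cccc(Cl)c2)C(c2cnc(CS)n2Nc2ccccc2)NC(=O)N1` — 98600 nM

The read-out throughout is an ADME assay on Vero cells (Chlorocebus sabaeus) for cytotoxicity, read by XTT assay, with a stated time of 72 h; a higher number here means that more compound is tolerated, a lower number that less compound is tolerated. In this assay compound 1 gives > 100000 nM, which is a limit of the assay and not a number. Compound 2 likewise gives > 100000 nM, again a limit rather than a number. The change between them is 4-chlorophenyl in place of 3-chlorophenyl on an amide-type nitrogen. Its step, a step that the two limits leave unreadable from compound 1 to compound 2, cannot be sized, due to the limit of > 100000 nM in this assay, at which 2 of the 3 values shown sit. Compound 3 is the only one of the three with a number: in this assay compound 3 gives 98600 nM. The difference between the core of compound 1 and the core of compound 3 is not broken down here.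

Compound 4 `CC1=C(C(=O)Nc2ccc(Cl)cc2)C(c2cnc(CS)n2Nc2ccccc2)NC(=O)N1` is not yet measured. It differs from compound 3 by 4-chlorophenyl in place of 3-chlorophenyl on an amide-type nitrogen. The place of this change is the same, word for word, as in the pair of compound 1 and compound 2, so it is the same change, made here for the second time. Because the earlier occurrence sits at the limit of > 100000 nM in this assay, at which 2 of the 3 values shown sit, its size gives no guide. What remains is the number for compound 3, which itself lies close to that limit.

The step from compound 3 to compound 4 is therefore expected to be small, a 1.0-fold higher number from compound 3 to compound 4 (0.01 log units; within the scatter), resting on compound 3 with 98600 nM. The value of compound 1 is a limit of the assay and adds no number to rest on. The value of compound 2 is likewise a limit. Compound 4 is expected to give 100000 nM. The expected range for compound 4 runs from 40000 nM to 250000 nM, with a real chance that this assay reports only a limit for compound 4.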

Compound 4, half-maximal cytotoxic concentration: > 100000 nM
Compound 4 gave a limit, no number (the forecaster's own chance of this, stated with the estimate: 55%); the middle value lies on the limit itself.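

In this assay compound 4 gives > 100000 nM, which is a limit of the assay and not a number. On these data alone, on the core of compound 3, 4-chlorophenyl in place of 3-chlorophenyl on the amide-type nitrogen reads as an at least 1.0-fold higher number from compound 3 to compound 4 (0.00 log units; that floor lies within the scatter), so on this core the change shows no step beyond the scatter, though only a floor is printed and the true size stays unknown. The same change has now been made on two cores and ends in a limit on both, which is all that can be said of carrying it over; the step on the core of compound 1 cannot be read, and whether the change has the same size on the two cores cannot be told, because neither occurrence gives a full size: the limit of > 100000 nM in this assay, at which 3 of the 4 values shown sit.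

The compounds shown leave open whether any group other than a chlorophenyl on the amide-type nitrogen, such as an aminophenyl or a carboxyphenyl ring, or a longer chain in place of the ring, would give a clear number in this assay. They also leave open how much the core alone contributes, as the pairs shown change only the chlorine position on the phenyl ring and no pair isolates a change of core.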